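Five-membered heteroaryl exchange on the chain carbon: compound 3

This account rests on a few compounds, and the source may have more. Where it says the series, first, only, none or still open, it means among the compounds named here.

Measured so far:
compound 1, `CCc1nc(C)c(CN2CCN(c3cccc4[nH]c(-c5ccc(C(C)(C)C)cc5)nc34)CC2)s1`, 120 nM
compound 2, `CCc1cc(CN2CCN(c3cccc4[nH]c(-c5ccc(C(C)(C)C)cc5)nc34)CC2)nn1C`, 350 nM

Both were run in an assay on isolated protein for displacement of a labelled ligand from Gonadotropin-releasing hormone receptor (Rattus norvegicus); a higher number here means a weaker inhibitor, a lower number a stronger inhibitor. Compound 2 holds the highest of the two numbers; its nearest neighbour is compound 1, and the difference is a 2.9-fold higher number from compound 1 to compound 2 (0.46 log units; beyond the scatter), a modest rise that lies beyond the scatter.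

Compound 3, `CCCn1cnc(CN2CCN(c3cccc4[nH]c(-c5ccc(C(C)(C)C)cc5)nc34)CC2)c1C`, is not yet measured. Relative to compound 2 the change is 5-methyl-1-propyl-1H-imidazol-4-yl in place of 5-ethyl-1-methyl-1H-pyrazol-3-yl on a saturated chain carbon bound to an amine nitrogen in a ring.

Among the measured compounds shown here, the only step that bears on this is the one from compound 1 to compound 2, where another exchange of the five-membered aromatic ring at the same place moved the number modestly. That step shows the ring at this position matters, but it gives no direction for a pyrazole-to-imidazole exchange combined with a longer chain on the ring nitrogen. The expectation is therefore a number near compound 2, with a step of a 1.4-fold lower number from compound 2 to compound 3 (0.15 log units; within the scatter) and room for a modest move either way. Compound 3 is estimated at 250 nM in this assay, within 80 nM to 800 nM.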

Compound 3, half-maximal inhibitory concentration: 47 nM
Compound 3: middle estimate off by 5.3-fold (0.73 log units), on the high side; measured number outside the range, below it.
By their numbers in this assay, from the lowest: compound 3; then compound 1; then compound 2.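

The five-membered aromatic group on a saturated chain carbon bound to an amine nitrogen in a ring can also lower the number in this assay: 5-methyl-1-propyl-1H-imidazol-4-yl in place of 5-ethyl-1-methyl-1H-pyrazol-3-yl gives a 7.4-fold lower number from compound 2 to compound 3 (0.87 log units; beyond the scatter), a step beyond the scatter and opposite in direction to the only earlier one. The same group also improves on 2-ethyl-4-methyl-1,3-thiazol-5-yl, with a 2.6-fold lower number from compound 1 to compound 3 (0.41 log units; beyond the scatter), so compound 3 is the strongest of the three and the thiazole no longer marks the best result at this place. No supporting measurement bears on why these exchanges move the number as they do.

The arrangement of the ring atoms and the substituents change together in each step, so the three compounds do not separate the imidazole ring from its propyl group. Open questions are whether a shorter ethyl or longer butyl chain in place of that propyl group would keep the number near that of compound 3, and how an amine or a carboxylic acid at the end of that chain would move it.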